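The source may hold more compounds than are shown below. What is called first, only, known or untested is meant among the compounds shown, and "the series" means these compounds.

Measured so far in an assay on isolated protein for binding affinity to 5-hydroxytryptamine receptor 1F (Homo sapiens), read by radioligand binding; on this read-out lower numbers stand for stronger inhibition and higher numbers for weaker inhibition:

Compound 1 `COc1c(NC(=O)c2ccc(F)cc2)cccc1C(=O)C1CCN(C)CC1`: 610 nM
Compound 2 `CN1CCC(C(=O)c2cccc(NC(=O)c3ccc(F)cc3)c2Cl)CC1`: 1700 nM
Compound 3 `Cc1c(NC(=O)c2ccc(F)cc2)cccc1C(=O)C1CCN(C)CC1`: 870 nM

Of these three numbers, compound 1 gives the lowest. The nearest of the other two lies a 1.4-fold higher number from compound 1 to compound 3 (0.15 log units; within the scatter), the furthest a 2.8-fold higher number from compound 1 to compound 2 (0.45 log units; beyond the scatter). The comparison between the other pair, a 2.0-fold lower number from compound 2 to compound 3 (0.29 log units; within the scatter), also stays inside the usual scatter, so only the swap to chloro stands out clearly.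

Compound 4 `CN1CCC(C(=O)c2cccc(NC(=O)c3ccc(F)cc3)c2F)CC1` has not yet been measured in this assay. It differs from compound 1 in one place: fluoro in place of methoxy on an aromatic carbon.

Among the compounds with values here, two measured steps bear on this change. Both replace the same methoxy group at this aromatic carbon. One is a 2.8-fold higher number from compound 1 to compound 2 (0.45 log units; beyond the scatter), a modest step beyond the scatter; the other is a 1.4-fold higher number from compound 1 to compound 3 (0.15 log units; within the scatter), a step inside it. Both replacements left a higher number than compound 1, and neither moved the number far. A new group at the same place is therefore expected to give at most a modest rise, possibly none beyond the scatter.

For compound 4 the estimated value in this assay is 1000 nM, with a range from 400 nM to 2500 nM. That estimate corresponds to an expected step of a 1.6-fold higher number from compound 1 to compound 4 (0.21 log units; within the scatter).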

Compound 4, inhibition constant: 8.3 nM
The estimate for compound 4 lay 120-fold (2.08 log units) above the measured number; the whole stated range lies above it.
By their numbers in this assay, from the lowest: compound 4; then compounds 1, 3 and 2 (each within the scatter of the next, the first and the last beyond it).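

In this assay, the aromatic carbon ortho to a (1-methylpiperidin-4-yl)carbonyl group proves far more sensitive to its substituent than the first three compounds suggested: fluoro brings a 73-fold lower number from compound 1 to compound 4 (1.87 log units; beyond the scatter), then a 100-fold lower number from compound 3 to compound 4 (2.02 log units; beyond the scatter), and a 200-fold lower number from compound 2 to compound 4 (2.31 log units; beyond the scatter). The earlier steps shown here among methoxy, methyl and chloro were modest at most, so those three groups alone gave no sign that a single replacement here could move the number so far, and fluoro now stands well apart from all of them. Nothing available here gives a measured reason for this gap.

The compounds shown leave open whether this large drop belongs to fluoro alone or would also appear with other groups on this carbon, such as a hydroxyl, an amine or a nitrile, or with plain hydrogen. Also open, going by these compounds, is whether the low number of compound 4 is specific to this receptor, and whether the same swap would have a similar effect if the rest of the core were changed.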